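Paw edema series: chloro added onto compound 3

The compounds below may be only part of what the source reports. "The series", "measured", "known", "first", "only" and "open" are said of these compounds alone.

Three compounds of this series carry a number in a functional assay on the whole organism for inhibition, with Rattus norvegicus as the target, read by paw edema, with stated times of 4 days, 1 h and 2 h, at a dose of 100 mg/kg by the oral route; a higher number here means more inhibition at the dose given (going by the name of the read-out), a lower number less inhibition. Compound 1 `CC1CCN(c2nc(-c3ccccc3)nc3ccc(Br)cc23)CC1` gives 57.8%. Compound 2 `CC1CCN(c2nc(-c3ccccc3)nc3ccc(I)cc23)CC1` gives 56.4%; the step of a number 1.4 percentage points lower from compound 1 to compound 2 (within the scatter) lies within the scatter. Compound 3 `Ic1ccc2nc(-c3ccccc3)nc(N3CCC(c4ccccc4)CC3)c2c1` gives 82.5%, and the step of a number 26.1 percentage points higher from compound 2 to compound 3 (beyond the scatter) is the only one beyond the scatter so far. Compound 3 therefore stands highest of the three numbers, beyond the scatter from both compound 1 and compound 2.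

Compound 4 `Clc1ccc(-c2nc(N3CCC(c4ccccc4)CC3)c3cc(I)ccc3n2)cc1` differs from compound 3 by chloro in place of hydrogen on an aromatic carbon. Neither measured step bears directly on this change: the first step swapped one halogen for another on the shared core and stayed within the scatter, the second replaced methyl with phenyl on the saturated ring and gave a modest rise. Nothing measured speaks to a chloro entering the phenyl group para to a large group. The working expectation for compound 4 is that the step of a number 2.5 percentage points lower from compound 3 to compound 4 (within the scatter) stays within the scatter, with the range widened for the lack of a matching precedent. Compound 4 is thus estimated at 80% in this assay, between 62% and 92%.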

Compound 4, a percentage reported as inhibition, in the whole organism at one dose (the size of the read-out at that dose, not a potency): 41.4%
Compound 4: the middle estimate sits 38.6 percentage points above what was measured; the measured number lies below the stated range.
By their numbers in this assay, from the lowest: compound 4; then compounds 2 and 1 (each within the scatter of the next); then compound 3.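

In this assay, the phenyl that becomes 4-chlorophenyl proves sensitive to a small change: a number 41.1 percentage points lower from compound 3 to compound 4 (beyond the scatter), with only one chlorine atom entering in place of a hydrogen. Among the compounds shown here, the earlier steps touched other parts of the series, the halogen on the shared core in a number 1.4 percentage points lower from compound 1 to compound 2 (within the scatter) and the group on the saturated ring in a number 26.1 percentage points higher from compound 2 to compound 3 (beyond the scatter), so this is the first reading at this place, and the fall is larger than the rise that came with phenyl in place of methyl. Nothing measured here accounts for this fall.

Only chloro is shown at this place, and whether the fall belongs to that group or to any group there stays open; fluoro, methoxy or an amine in its stead would tell these readings apart. Also open, on these data alone, is whether the change from phenyl to 4-chlorophenyl gives a step of this size on compound 1 or compound 2, which carry methyl on the saturated ring, and how the numbers would stand at other doses.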